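The source may report more compounds than this note shows. Statements on the series, on what has been measured and on what is new or still open speak of the compounds shown alone.

This is a small set of four compounds built on two closely related cores. Compound 1 `CCCC(=O)c1c(OC)c(Cl)c(OC)c(Cl)c1OC` and compound 2 `CCCCC(=O)c1c(OC)c(Cl)c(OC)c(Cl)c1OC` share one core, while compound 3 `CCCCCCCC(=O)c1c(O)c(Cl)c(O)c(Cl)c1O` and the not yet measured compound 4 `CCCCCCCCC(=O)c1c(O)c(Cl)c(O)c(Cl)c1O` share the other; the difference between the two cores is not broken down here.

In an ADME assay on the whole organism (strain S2) for cytotoxicity, with Drosophila as the target, read by WST assay (a higher number here means that more compound is tolerated, a lower number that less compound is tolerated), compound 1 gives 144000 nM, and compound 2 gives 149000 nM. The change between them is methyl in place of hydrogen on a saturated chain carbon, three bonds along the chain from a carbonyl carbon. The step it made was a 1.0-fold higher number from compound 1 to compound 2 (0.01 log units; within the scatter), so the two numbers cannot be told apart.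

In this assay compound 3 gives 88500 nM. This number and those of compound 1 and compound 2 all lie within the scatter of one another, so nothing separates the three. Compound 4 arises from compound 3 by methyl in place of hydrogen on a saturated chain carbon, seven bonds along the chain from a carbonyl carbon. This is the same kind of change as from compound 1 to compound 2, but not the same: there the methyl enters on a saturated chain carbon three bonds along the chain from a carbonyl carbon, here on a saturated chain carbon seven bonds along the chain from a carbonyl carbon, and the core differs as well.

Because the like change in the first pair made a 1.0-fold higher number from compound 1 to compound 2 (0.01 log units; within the scatter), the step from compound 3 to compound 4 is expected to be about a 1.1-fold lower number from compound 3 to compound 4 (0.04 log units; within the scatter), with some allowance for the different core and the more distant place. Compound 4 is therefore expected to give roughly 80000 nM in this assay, most likely somewhere between 45000 nM and 140000 nM.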

Compound 4, half-maximal cytotoxic concentration: 82800 nM
For compound 4 the middle estimate is 1.0-fold (0.01 log units) below the measured one, and the stated range covers the measured number.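

In this assay, within the data shown here, the extra methyl at the end of the chain gives a 1.1-fold lower number from compound 3 to compound 4 (0.03 log units; within the scatter), a step that cannot be told apart from no step at all. Set beside the same change on the other core, this step agrees with the earlier one: the same change on two cores in this assay, a 1.0-fold higher number (0.01 log units; within the scatter) from compound 1 to compound 2 and a 1.1-fold lower number (0.03 log units; within the scatter) from compound 3 to compound 4, 1.1-fold (0.04 log units) apart, within the scatter of two such steps. This shows that, for these two pairs, adding one carbon to the end of a plain chain leaves the number within the scatter on both cores, but it does not show that the change would behave alike on any other core or in any other assay, and the agreement of two very small steps is a weak test, as the pairs also differ in where the methyl enters, so the core and the place cannot be separated.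

The compounds shown carry only plain saturated chains on the carbonyl, so it stays open whether a much longer chain, a branched chain, or a chain ending in an amine or a carboxylic acid would give a step beyond the scatter. What the difference between the two cores does on its own also stays open, as each pair shown changes only the chain.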